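Hydroxy to carboxy on the quinoline-type core, second instance

The compounds below may be only part of what the source reports. "The series", "measured", "known", "first", "only" and "open" are said of these compounds alone.

Measured so far:
compound 1, `Cc1c(C(=O)Nc2c(F)cc(-c3cccc(F)c3)cc2F)nc2ccc(F)cc2c1O` — 31.3%
compound 2, `COc1ccc2nc(C(=O)Nc3ccc(-c4ccccc4)cc3)c(C)c(O)c2c1` — 36.3%
compound 3, `Cc1c(C(=O)Nc2c(F)cc(-c3cccc(F)c3)cc2F)nc2ccc(F)cc2c1C(=O)O` — 26.3%

In a functional assay on Hep 3B2 cells (Homo sapiens) for antiproliferative activity, read by MTT assay, with a stated time of 24 h, tested at 11.11 ug/mL (a lower number here means a weaker effect, a higher number a stronger effect of the compound at the concentration tested), compound 1 gives 31.3%. Compound 3, `Cc1c(C(=O)Nc2c(F)cc(-c3cccc(F)c3)cc2F)nc2ccc(F)cc2c1C(=O)O`, differs from it in one place: carboxy in place of hydroxy on an aromatic carbon. The step of a number 5 percentage points lower from compound 1 to compound 3 (within the scatter) is within the scatter, so this exchange made no resolvable difference on the core of compound 1.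

Compound 2, `COc1ccc2nc(C(=O)Nc3ccc(-c4ccccc4)cc3)c(C)c(O)c2c1`, gives 36.3% in this assay. Its value lies within the scatter of both compound 1 and compound 3; no order among the three can be read from these numbers. How the core of compound 2 differs from the core of compound 1 is not broken down here.

Compound 4, `COc1ccc2nc(C(=O)Nc3ccc(-c4ccccc4)cc3)c(C)c(C(=O)O)c2c1`, is not yet measured. It carries the same change on the core of compound 2: carboxy in place of hydroxy on an aromatic carbon. The place around the exchanged group is described in the same words for both pairs, so this is the same change, seen a second time among these four compounds.

Among the compounds with values here, with only one measured instance, the expectation rests on compound 1 and compound 3 and the step of a number 5 percentage points lower from compound 1 to compound 3 (within the scatter). The estimated step of a number 5.3 percentage points lower from compound 2 to compound 4 (within the scatter) is expected to be of like size, that is, within the scatter. Compound 4 is therefore estimated at 31% in this assay, with a range from 18% to 44%. Whether the change behaves alike on the core of compound 2 is not established by any other pair here.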

Compound 4, a percentage reported as inhibition, at one concentration (the size of the read-out at that concentration, not a potency): 28.3%
Compound 4: middle estimate off by 2.7 percentage points, on the high side, and the stated range covers the measured number.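

In this assay, carboxy in place of hydroxy on an aromatic carbon on the second core reads as a number 8 percentage points lower from compound 2 to compound 4 (within the scatter). Set beside the first instance, the exchange carries over from one core to the other without a resolvable difference between the two steps: the same change on two cores in this assay, a number 5 percentage points lower (within the scatter) from compound 1 to compound 3 and a number 8 percentage points lower (within the scatter) from compound 2 to compound 4, 3 percentage points apart, within the scatter of two such steps This is agreement between two steps that are each within the scatter, so it shows only that neither core gives a resolvable effect of the exchange under these conditions; it does not show that hydroxy and carboxy are interchangeable in general, that the same would hold on a third core, or that the effect would stay alike at other concentrations, as the read-out comes from a single concentration.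

Still open, as far as these compounds go, is whether another group on the same aromatic carbon, such as an amine, a primary amide or a methyl ester, would give a step beyond the scatter on either core. Also open, from the compounds shown here alone, is whether the outcome of the exchange depends on the neighbouring methyl group, which a longer chain or a hydrogen in its place would test, and the two cores cannot be compared directly here, as they differ in more than one place.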